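Working notes: 4-methylphenyl to 4-fluorophenyl

A few compounds are considered here, and "the series" means these few. Any claim that something is new, unique, unknown or untested is made for them only; others in the source may bear on it.

compound 1 `O=C(NNc1ccccc1Cl)c1cccc(NS(=O)(=O)c2cnc(O)nc2O)c1` gives 1460 nM
compound 2 `Cc1ccccc1C(=O)NNC(=O)c1cccc(NS(=O)(=O)c2cnc(O)nc2O)c1` gives 8010 nM
compound 3 `Cc1ccc(C(=O)NNC(=O)c2cccc(NS(=O)(=O)c3cnc(O)nc3O)c2)cc1` gives > 20000 nM

Compound 3 stands at > 20000 nM in a functional assay on A549 cells (Homo sapiens) for antiproliferative activity, read by MTT assay, with a stated time of 24 h (on this read-out lower numbers stand for stronger inhibition and higher numbers for weaker inhibition), as a limit and not a number. Compound 4 `O=C(NNC(=O)c1cccc(NS(=O)(=O)c2cnc(O)nc2O)c1)c1ccc(F)cc1` carries fluoro in place of methyl on an aromatic carbon, para to a large group (fluoro in place of methyl on an aromatic carbon). Among the compounds with values here, no measured step makes this exchange. The closest is an at least 2.4-fold higher number from compound 2 to compound 3 (0.39 log units; beyond the scatter) and it concerns the same methyl, while an at least 13-fold higher number from compound 1 to compound 3 (1.13 log units; beyond the scatter) is larger. Both end at the limit, so neither gives the size of the exchange. The expected change in this assay is small and, if any, toward a lower number (an at least 1.3-fold lower number from compound 3 to compound 4 (0.12 log units; that floor lies within the scatter)). Compound 4 is estimated at 15000 nM with an expected range from 6000 nM to 20000 nM and may again return only a limit.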

Compound 4, half-maximal inhibitory concentration: > 20000 nM
Compound 4: only a limit was reported; the forecaster's own chance of this, stated with the estimate: 50%; at least 1.3-fold (0.12 log units) between middle value and limit.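

In this assay compound 4 gives > 20000 nM, a limit and not a number. The exchange of methyl for fluoro on this aromatic carbon, para to a large group, cannot be read, since both ends of the step are limits: the limit of > 20000 nM in this assay, at which 2 of the 4 values shown sit. Within the data shown here, with fluoro as with methyl, the series stays clearly apart from the earlier compounds, with an at least 2.4-fold higher number from compound 2 to compound 4 (0.39 log units; beyond the scatter) and an at least 13-fold higher number from compound 1 to compound 4 (1.13 log units; beyond the scatter).

As far as these compounds go, how far compound 3 and compound 4 lie past the limit stays open. Also open, from the compounds shown here alone, is what an amine or a carboxylic acid on this aromatic carbon would give in this assay.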